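Removing tert-butoxycarbonyl from compound 1

The compounds below may be only part of what the source reports. "The series", "measured", "known", "first", "only" and "open" are said of these compounds alone.

Compound 1 `CC(C)(C)OC(=O)NCc1ccccc1NC(=O)c1cc2cc([N+](=O)[O-])ccc2s1` is measured in a physicochemical assay for solubility (a higher number here means a more soluble compound, a lower number a less soluble compound), and gives < 5 ug/mL, which is a limit of the assay and not a number. Within the data shown here, the series so far shows (the limit of < 5 ug/mL in this assay, at which 1 of the 3 values shown sits). Two other compounds return numbers: compound 2 `COc1ccc2[nH]c(C(=O)Nc3ccccc3C(N)=O)cc2c1` gives 10 ug/mL, and compound 3 `COC(=O)c1cccc(NC(=O)c2cc3cc([N+](=O)[O-])ccc3s2)c1` gives 25 ug/mL.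

Compound 4 `NCc1ccccc1NC(=O)c1cc2cc([N+](=O)[O-])ccc2s1` carries hydrogen in place of tert-butoxycarbonyl on an amine nitrogen. Among the measured compounds shown here, no measured pair shows this change, and compound 1 offers only a limit as a starting point, so the size of the step is poorly fixed. A rise in this assay beyond the usual scatter is expected, with a landing in the same region as the numbers for compound 2 and compound 3. The estimated step is an at least 5.0-fold higher number from compound 1 to compound 4 (0.69 log units; beyond the scatter). Compound 4 is expected at 25 ug/mL, with an estimated range of 7 ug/mL to 90 ug/mL.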

Compound 4, solubility: 1000 ug/mL
Beside the measured number, compound 4's estimate is 40-fold (1.60 log units) below it; measured number above the stated range.
By their numbers in this assay, from the lowest: compound 2; then compound 3; then compound 4. At a limit, below all of these: compound 1.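

In this assay this position responds strongly to the change, with an at least 200-fold higher number from compound 1 to compound 4 (2.30 log units; beyond the scatter). Among these compounds, compound 1 gives a limit of the assay and not a number, so this step sets only a floor on the true size of the change: the limit of < 5 ug/mL in this assay, at which 1 of the 4 values shown sits. Compound 2 and compound 3 differ from compound 4 in more than one place, so only the pair of compound 1 and compound 4 reads this change directly.

On these data alone, it remains open whether the step depends on a free amine hydrogen pair or would also appear with a single methyl or an acetyl on the same nitrogen. Also unresolved is whether a longer chain carrying the amine, or a carboxylic acid in place of aminomethyl, would keep a number in the range of compound 4.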